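The compounds below may be only part of what the source reports. "The series", "measured", "known", "first", "only" and "open" are said of these compounds alone.

Compound 2 `C=CCc1ccc(OC(=O)c2ccncc2)c(OC)c1` stands lowest of the two compounds measured in a physicochemical assay for lipophilicity; a lower number here means a more polar compound, a higher number a more lipophilic compound: compound 2 gives 0.86, while compound 1 `C=CCc1ccc(OC(=O)c2cccc(Cl)c2)c(OC)c1` gives 2.79. For the measured compounds named here, the only measured step, a number 1.93 log units lower from compound 1 to compound 2 (beyond the scatter), is of a different kind, a pyridin-4-yl put in place of a 3-chlorophenyl, and so it does not bear directly on the change now considered. Compound 3 `C=CCc1ccc(OC(=O)c2cccnc2)c(OC)c1` differs from compound 2 in one place: pyridin-3-yl in place of pyridin-4-yl on a carbonyl carbon. Going by the values given here, the two share every atom and differ only in how the ring is joined, and no measured pair shows what such a rearrangement does in this assay. Compound 3 is therefore expected to sit close to compound 2, with a step of a number 0.14 log units higher from compound 2 to compound 3 (within the scatter) that is estimated to lie within the scatter. For compound 3 the estimate in this assay is 1, with a range from 0.6 to 1.4.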

Compound 3, partition coefficient: 0.86
For compound 3 the middle estimate is 0.14 log units above the measured one; the range from low to high includes it.
By their numbers in this assay, from the lowest: compounds 2 and 3 (each within the scatter of the next); then compound 1.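

In this assay, for the compounds shown here, the change of attachment from pyridin-4-yl to pyridin-3-yl on the carbonyl carbon gives no change at the digits printed from compound 2 to compound 3 (within the scatter) and so provides the first measured pair of this kind. Replacing 3-chlorophenyl with pyridin-3-yl gives a number 1.93 log units lower from compound 1 to compound 3 (beyond the scatter) and shows that the large step seen earlier at this position is not limited to pyridin-4-yl, while the two pyridine isomers cannot be told apart in this measurement. Nothing available here accounts for their matching numbers.

As far as these compounds go, it remains open whether pyridin-2-yl on the same carbonyl carbon would fall with compound 2 and compound 3, or whether an amine or a carboxylic acid on the pyridine ring would move the number. The three compounds also leave open whether the match between the two isomers extends beyond this assay.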